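A few compounds are considered here, and "the series" means these few. Any claim that something is new, unique, unknown or untested is made for them only; others in the source may bear on it.

Measured compounds, with their numbers in an assay on CHO cells for binding affinity to metabotropic glutamate receptor 2 (Rattus norvegicus); a lower number here means a stronger inhibitor, a higher number a weaker inhibitor: compound 1 `N[C@]1(C(=O)O)[C@H]2[C@@H](C[C@H]1OCc1cccc(Br)c1)[C@]2(F)C(=O)O` gives 4.71 nM. Compound 2 `N#Cc1cccc(CO[C@@H]2C[C@@H]3[C@H]([C@]2(N)C(=O)O)[C@@]3(F)C(=O)O)c1` gives 2.94 nM. Compound 3 `N[C@]1(C(=O)O)[C@H]2[C@@H](C[C@H]1OCc1cccc(Oc3ccccc3)c1)[C@]2(F)C(=O)O` gives 7.15 nM.

Compound 3 carries the highest number of the three; its gap to compound 1 lies within the scatter, while its gap to compound 2 lies beyond it. Compound 4 `Nc1cccc(CO[C@@H]2C[C@@H]3[C@H]([C@]2(N)C(=O)O)[C@@]3(F)C(=O)O)c1` arises from compound 3 by amino in place of phenoxy on an aromatic carbon. The measured steps that bear on this are the two that put phenoxy onto that same aromatic carbon: a 1.5-fold higher number from compound 1 to compound 3 (0.18 log units; within the scatter) and a 2.4-fold higher number from compound 2 to compound 3 (0.39 log units; beyond the scatter). Replacing phenoxy with bromo or cyano thus gave numbers no higher than that of compound 3, so swapping phenoxy for amino is expected to give a modestly lower number, a 1.8-fold lower number from compound 3 to compound 4 (0.25 log units; within the scatter). Compound 4 is therefore estimated at 4 nM, between 1.5 nM and 12 nM.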

Compound 4, inhibition constant: 15.4 nM
For compound 4 the middle estimate is 3.9-fold (0.59 log units) below the measured one, outside the stated range (above it).
By their numbers in this assay, from the lowest: compounds 2, 1 and 3 (each within the scatter of the next, the first and the last beyond it); then compound 4.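

Among the four groups on this aromatic carbon, amino gives the highest number in this assay, with a 2.2-fold higher number from compound 3 to compound 4 (0.33 log units; beyond the scatter) and a 3.3-fold higher number from compound 1 to compound 4 (0.51 log units; beyond the scatter) and a 5.2-fold higher number from compound 2 to compound 4 (0.72 log units; beyond the scatter). Exchanging the whole phenoxy group for amino therefore did not lower the number, so a smaller group here does not by itself mean a lower one. Nothing measured here explains this rise.

The compounds shown leave open whether a hydroxyl group on this carbon would behave like amino. They also leave open how a methylamino or acetamido group would compare.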